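From compound 3 to compound 4: an aryl exchange

The compounds below may be only part of what the source reports. "The series", "measured", "known", "first", "only" and "open" are said of these compounds alone.

In a functional assay on MGC-803 cells (Homo sapiens) for antiproliferative activity, read by MTT assay, with a stated time of 72 h (a higher number here means a weaker inhibitor, a lower number a stronger inhibitor), compound 3 `O=C(NO)c1ccc(NCc2nc(-c3ccccc3)nn2-c2cccc(Cl)c2)cc1` gives 13700 nM. In the same test, compound 1 `Cc1ccccc1-n1nc(-c2ccccc2)nc1CNc1ccc(C(=O)NO)cc1` gives 12300 nM, and compound 2 `COc1ccc(-n2nc(-c3ccccc3)nc2CNc2ccc(C(=O)NO)cc2)cc1` gives 7050 nM. Compound 3 therefore stands level with both others, with nothing on these numbers to separate it from either.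

Compound 4 `O=C(NO)c1ccc(NCc2nc(-c3ccccc3)nn2-c2ccc(F)cc2)cc1` differs from compound 3 as follows: 4-fluorophenyl in place of 3-chlorophenyl on an aromatic nitrogen. In words, it has 4-fluorophenyl in place of 3-chlorophenyl on an aromatic nitrogen. Three measured steps exchange the group at this same place: a 1.7-fold lower number from compound 1 to compound 2 (0.24 log units; within the scatter), a 1.1-fold higher number from compound 1 to compound 3 (0.05 log units; within the scatter) and a 1.9-fold higher number from compound 2 to compound 3 (0.29 log units; within the scatter). For the measured compounds named here, all three stay within the scatter, although none of the measured compounds carries 4-fluorophenyl, so the exchange itself remains untested. On this evidence, no step beyond the scatter is expected in this assay. The estimated change is a 1.4-fold lower number from compound 3 to compound 4 (0.14 log units; within the scatter), with no firm direction implied. Compound 4 is expected at about 10000 nM, with an estimated range of 4500 nM to 22000 nM.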

Compound 4, half-maximal inhibitory concentration: 10500 nM
Compound 4: middle estimate off by 1.1-fold (0.02 log units), on the low side; the measured number falls inside the stated range.
By their numbers in this assay, from the lowest: compounds 2, 4, 1 and 3 (each within the scatter of the next).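

In this assay, 4-fluorophenyl on the aromatic nitrogen stays level with all three earlier aryl groups: a 1.3-fold lower number from compound 3 to compound 4 (0.12 log units; within the scatter), a 1.5-fold higher number from compound 2 to compound 4 (0.17 log units; within the scatter) and a 1.2-fold lower number from compound 1 to compound 4 (0.07 log units; within the scatter). Fluoro-substituted phenyl therefore joins the methyl-, methoxy- and chloro-substituted phenyl groups, and across these four compounds no exchange at this position gives a step beyond the scatter. The data shown include no measurement that bears on why this position stays so flat.

Going by these compounds, it remains open whether an amine or a carboxylic acid on this phenyl ring, or a longer chain in its place on the aromatic nitrogen, would give a step beyond the scatter. On these data alone, the effect of replacing the phenyl group shared by all four compounds also remains open.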